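Swapping the Halogenated Ring for a Methylphenyl

This account rests on a few compounds, and the source may have more. Where it says the series, first, only, none or still open, it means among the compounds named here.

Going by the values given here, compound 3 `O=c1c2ccccc2[se]n1-c1nnc(-c2ccccc2Br)s1` gives 12700 nM in a functional assay on A549 cells (Homo sapiens) for antiproliferative activity, read by CCK-8 assay, with a stated time of 48 h (on this read-out lower numbers stand for stronger inhibition and higher numbers for weaker inhibition), the second highest of the three numbers measured so far; compound 1 `O=c1c2ccccc2[se]n1-c1nnc(-c2ccc(Cl)cc2)s1` gives 10400 nM and compound 2 `O=c1c2ccccc2[se]n1-c1nnc(-c2ccc(F)cc2)s1` gives 21100 nM. Compound 4 `Cc1ccc(-c2nnc(-n3[se]c4ccccc4c3=O)s2)cc1` differs from compound 3 by 4-methylphenyl in place of 2-bromophenyl on an aromatic carbon. Among the compounds with values here, the steps that bear on this also change the ring attached to the shared core: a 1.2-fold higher number from compound 1 to compound 3 (0.09 log units; within the scatter) and a 1.7-fold lower number from compound 2 to compound 3 (0.22 log units; within the scatter) both stayed within the scatter, while a 2.0-fold higher number from compound 1 to compound 2 (0.31 log units; beyond the scatter) was modest. Within the data shown here, no measured compound carries a methyl group, so the 4-methylphenyl itself is untested. The change is therefore expected to be small, at most modest in either direction, and for compound 4 the estimated step is a 1.1-fold higher number from compound 3 to compound 4 (0.04 log units; within the scatter). Compound 4 is expected to give 14000 nM, with a range from 6500 nM to 32000 nM.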

Compound 4, half-maximal inhibitory concentration: 13400 nM
Estimate against measurement, compound 4: 1.0-fold (0.02 log units) above; the range from low to high includes it.
By their numbers in this assay, from the lowest: compounds 1, 3, 4 and 2 (each within the scatter of the next, the first and the last beyond it).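

In this assay a ring carrying only carbon, with a methyl group in place of a halogen, stays within the scatter of all three halogen-bearing compounds (a 1.1-fold higher number from compound 3 to compound 4 (0.02 log units; within the scatter)), (a 1.6-fold lower number from compound 2 to compound 4 (0.20 log units; within the scatter)) and (a 1.3-fold higher number from compound 1 to compound 4 (0.11 log units; within the scatter)). At this position, then, 4-methylphenyl cannot be told apart from 2-bromophenyl, 4-fluorophenyl or 4-chlorophenyl. No available evidence explains this result.

Still open, on these data alone, is whether an amine or a carboxylic acid on this phenyl ring would move the number beyond the scatter. A longer chain in place of the methyl group poses the same question.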